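The compounds below may be only part of what the source reports. "The series", "measured", "known", "first", "only" and "open" are said of these compounds alone.

Results so far in an ADME assay on the whole organism (Rattus norvegicus) for pharmacokinetics, at a dose of 1 mg/kg by the intravenous route (on this read-out lower numbers stand for narrower distribution and higher numbers for wider distribution into tissues), are
- compound 1 `COc1ccc(F)cc1-c1ccnc2[nH]c(C3=CCC(C(=O)O)CC3)cc12` with 0.51 L/kg as its value
- compound 2 `COc1ccc(F)cc1-c1ccnc2[nH]c(C3=CCN([C@H]4CC[C@H](C(=O)O)CC4)CC3)cc12` with 1.9 L/kg as its value
- compound 3 `COc1ccc(F)cc1-c1c(F)cnc2[nH]c(C3=CCN([C@H]4CC[C@H](C(=O)O)CC4)CC3)cc12` with 2.7 L/kg as its value

Compound 3 sits level with compound 2 within the scatter, and both lie clearly above compound 1.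

Compound 4 `COc1ccc(F)cc1-c1c(F)cnc2[nH]c(C3=CCN([C@H]4CC[C@H](CC(=O)O)CC4)CC3)cc12` differs from compound 3 in one place, described as carboxymethyl in place of carboxy on a saturated ring carbon in the count. In words, this is carboxymethyl in place of carboxy on a saturated ring carbon.

For the measured compounds named here, no measured step involves this change. Going by the values given here, the only single-place step is a 1.4-fold higher number from compound 2 to compound 3 (0.15 log units; within the scatter) and it came from fluoro in place of hydrogen on an aromatic carbon, so it offers only a weak hint that one small edit may leave the number in place. No step beyond the scatter is therefore expected in this assay, and the data favour no direction. The estimated change is a 1.1-fold lower number from compound 3 to compound 4 (0.03 log units; within the scatter) and nothing larger is expected. Compound 4 is estimated at 2.5 L/kg with an expected range from 1.3 L/kg to 4.8 L/kg for its measurement.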

Compound 4, volume of distribution at steady state: 2.9 L/kg
Compound 4: middle estimate off by 1.2-fold (0.06 log units), on the low side, within the range that was stated.
By their numbers in this assay, from the lowest: compound 1; then compounds 2, 3 and 4 (each within the scatter of the next).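

In this assay, carboxymethyl in place of carboxy on this saturated ring carbon gives a 1.1-fold higher number from compound 3 to compound 4 (0.03 log units; within the scatter), so the two compounds read as level. Among the compounds shown, this is the only edit at this position, and it indicates that extending 4-carboxycyclohexyl to 4-(carboxymethyl)cyclohexyl does not move the number past the usual scatter, at least in this one pair. Nothing available here offers a reason for this result.

Still open, as far as these compounds go, is whether a longer chain ending in a carboxylic acid, or a primary amide or an amine at the same ring carbon, would also leave the number in place. This single pair also cannot say whether the same edit would read the same on compound 2, which carries hydrogen where compound 3 carries fluoro.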